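The source may report more compounds than this note shows. Statements on the series, on what has been measured and on what is new or still open speak of the compounds shown alone.

Compound 1 `Brc1ccc(Cn2cc(CSc3nnc(-c4ccccc4)c(-c4ccccc4)n3)nn2)cc1` gives only a limit in a functional assay on ECa-109 cells for antiproliferative activity against ECa-109 cell line (Homo sapiens), read by MTT assay, with a stated time of 48 h (a lower number here means a stronger inhibitor, a higher number a weaker inhibitor), namely > 100000 nM. Compound 2 `Cc1ccc(Cn2cc(CSc3nnc(-c4ccccc4)c(-c4ccccc4)n3)nn2)cc1` gives 12400 nM. Compound 3 `COc1ccc(C(=O)/C=C/c2ccc(-n3cc(CSc4nnc(-c5ccccc5)c(-c5ccccc5)n4)nn3)cc2)cc1` again gives only a limit, > 100000 nM.

Compound 3 thus stands at the limit of > 100000 nM in this assay, at which 2 of the 3 values shown sit; only compound 2 yields a number. Among the measured compounds shown here, the single measured step, an at least 8.0-fold lower number from compound 1 to compound 2 (0.90 log units; beyond the scatter), concerns a different group at a different place on the shared core and is the only scale the series offers. The change to compound 4 `NS(=O)(=O)c1ccc(-n2cc(CSc3nnc(-c4ccccc4)c(-c4ccccc4)n3)nn2)cc1` is sulfamoyl in place of 2-((4-methoxyphenyl)carbonyl)ethenyl on an aromatic carbon. For the measured compounds named here, no measured step shares this position, and a limit for compound 3 gives no starting number, so direction and size stay open. Compound 4 is expected to give about 50000 nM in this assay, within 8000 nM to 100000 nM. The step of an at least 2.0-fold lower number from compound 3 to compound 4 (0.30 log units; that floor lies within the scatter) is expected only loosely, and a further limit is about as likely as a number.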

Compound 4, half-maximal inhibitory concentration: > 100000 nM
Compound 4: only a limit was reported (the forecaster's own chance of this, stated with the estimate: 50%); middle value at least 2.0-fold (0.30 log units) away from the limit.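

With sulfamoyl in place of 2-((4-methoxyphenyl)carbonyl)ethenyl, compound 4 also gives only a limit in this assay, > 100000 nM. Among the compounds shown here, replacing 4-methylbenzyl with 4-sulfamoylphenyl on the aromatic nitrogen gives an at least 8.0-fold higher number from compound 2 to compound 4 (0.90 log units; beyond the scatter), so this change loses the only measured number. The steps to compound 4 from compound 3 and from compound 1 cannot be read, and the series gathers at its ceiling: the limit of > 100000 nM in this assay, at which 3 of the 4 values shown sit.

From the compounds shown here alone, whether an amine or a carboxylic acid on this aromatic carbon would give a number remains open. Also open, going by these compounds, is whether a longer chain on the aromatic nitrogen would keep the number seen with 4-methylbenzyl.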